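The compounds below may be only part of what the source reports. "The series", "measured", "known", "first", "only" and "open" are said of these compounds alone.

Among the compounds with values here, in an ADME assay on blood (Rattus norvegicus) for metabolic stability, with a stated time of 2 h (a lower number here means that less of the compound is left, a higher number that more of the compound is left), compound 2 (`CC/C(=N/O)c1ccc2oc(CSc3nnc(CNc4ccccc4)n3CC)nc2c1`) gives 100% as the only number, so it cannot yet be ranked against any other compound. Compound 1 (`CC/C(=N/OC)c1ccc2oc(CSc3nnc(CNc4ccccc4)n3CC)nc2c1`) is recorded as "not determined" (no result reported) and offers no comparison. Compound 3 (`CCn1c(CNc2ccccc2)nnc1SCc1nc2cc(OC(F)(F)F)ccc2o1`) has yet to be measured. It differs from compound 2 by one substitution on an aromatic carbon (a group of 5 heavy atoms (1 carbon, 1 oxygen, 3 fluorine; no ring) in place of a group of 5 heavy atoms (3 carbon, 1 nitrogen, 1 oxygen; no ring), on an aromatic carbon), with trifluoromethoxy entering. Within the data shown here, no step between measured compounds is available to size this change. With compound 2 at 100% there is little room for a rise, so any real movement is expected to be downward. The estimated step (a number 10 percentage points lower from compound 2 to compound 3 (within the scatter)) is small and may not exceed the usual scatter. Compound 3 is expected at 90% (estimated range 70% to 100%) in this read-out.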

Compound 3, percent of the compound remaining: 100%
For compound 3 the middle estimate is 10 percentage points below the measured one; low and high end bracket the measured number.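

Replacing the group that leaves with trifluoromethoxy on this aromatic carbon gives no change at the digits printed from compound 2 to compound 3 (within the scatter) in this assay, the first comparison the series allows. The position therefore carries a substituent with no double bond outside aromatic rings and no hydrogen-bond donor, with no change in the percent remaining, which compound 2 alone could not show. The two groups have the same heavy-atom count. This step says nothing about a change in group size. No supporting measurement is available to explain the result.

Compound 2 and compound 3 share one printed value, so nothing shown identifies a group at this position that leaves less of the compound after the stated time. Going by these compounds, an amine or a carboxylic acid here, or a longer chain in place of the ethyl group on the shared core, remains open.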